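The compounds below may be only part of what the source reports. "The series", "measured", "known", "first", "only" and "open" are said of these compounds alone.

Measured compounds:
- compound 1 `CN(C)CCn1cnnc1-c1cc(Oc2ccc(NC(=O)N/N=C/c3ccc(Cl)cc3Cl)cc2F)ccn1` — 390 nM in a functional assay on HT-29 cells (Homo sapiens) for cytotoxicity, read by MTT assay, with a stated time of 72 h; on this read-out lower numbers stand for stronger inhibition and higher numbers for weaker inhibition
- compound 2 `COc1ccc(/C=N/NC(=O)Nc2ccc(Oc3ccnc(-c4nncn4CCN(C)C)c3)c(F)c2)c(OC)c1OC` — 3970 nM in this assay

Compound 1 stands lowest of the two numbers in this assay; its nearest neighbour is compound 2, reached by a 10-fold higher number from compound 1 to compound 2 (1.01 log units; beyond the scatter). The pair share the whole core and differ only in the aryl group on the carbon with a double bond to nitrogen, and that single exchange already accounts for a large step.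

Compound 3 `CN(C)CCn1cnnc1-c1cc(Oc2ccc(NC(=O)N/N=C/c3cccc(O)c3)cc2F)ccn1` is not yet measured. Against compound 1 the change is 3-hydroxyphenyl in place of 2,4-dichlorophenyl on a carbon with a double bond to nitrogen. Going by the values given here, the one step that bears on it is the exchange at the same position, a 10-fold higher number from compound 1 to compound 2 (1.01 log units; beyond the scatter), which moved the number sharply upward. Among the compounds with values here, the group entering in compound 3 is not the one tested there, so that step is only a rough guide; still, the one comparison available shows that leaving 2,4-dichlorophenyl at this carbon costs potency, and a step in the same direction, smaller than the one seen, is expected.

Compound 3 is therefore estimated at 1200 nM in this assay, within a range from 400 nM to 4000 nM, which corresponds to an expected step of a 3.1-fold higher number from compound 1 to compound 3 (0.49 log units; beyond the scatter).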

Compound 3, half-maximal inhibitory concentration: 330 nM
Compound 3: middle estimate off by 3.6-fold (0.56 log units), on the high side, and the stated range ends above it.
By their numbers in this assay, from the lowest: compounds 3 and 1 (each within the scatter of the next); then compound 2.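

At the carbon with a double bond to nitrogen, 2,4-dichlorophenyl turns out not to be required: in this assay its exchange for 3-hydroxyphenyl gives a 1.2-fold lower number from compound 1 to compound 3 (0.07 log units; within the scatter) even though both chlorine atoms leave and a hydrogen-bond donor enters. Going by these compounds alone, the earlier step can therefore no longer be read as a general cost of leaving 2,4-dichlorophenyl, and a 12-fold lower number from compound 2 to compound 3 (1.08 log units; beyond the scatter) in this assay sets 2,3,4-trimethoxyphenyl apart as the one group of the three with a clearly higher number. Nothing measured on these compounds accounts for the difference between the three aryl groups.

Still open, on these data alone, is whether the number at this carbon holds with an unsubstituted phenyl, or with a phenyl carrying an amine or a carboxylic acid in place of the hydroxyl, which would show whether the hydroxyl contributes at all. Also open, as far as these compounds go, is how much of the higher number of compound 2 belongs to any single methoxy group, as against all three together.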